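From Vinyl to Propyl on a Shared Core

The source may report more compounds than this note shows. Statements on the series, on what has been measured and on what is new or still open speak of the compounds shown alone.

Three measured compounds share one core and differ only in the group on a saturated ring carbon. Compound 1 `C=C[C@@H]1O[C@H](COCc2ccccc2)[C@@H](OCc2ccccc2)[C@H](OCc2ccccc2)[C@H]1O` carries a vinyl group there, while compound 2 `CC(C)C[C@H]1O[C@H](COCc2ccccc2)[C@@H](OCc2ccccc2)[C@H](OCc2ccccc2)[C@@H]1O` and compound 3 `CC(C)(C)C[C@H]1O[C@H](COCc2ccccc2)[C@@H](OCc2ccccc2)[C@H](OCc2ccccc2)[C@H]1O` carry branched saturated chains. In a functional assay on HL-60 cells (Homo sapiens) for antiproliferative activity, read by MTT assay (a lower number here means a stronger inhibitor, a higher number a weaker inhibitor), compound 1 gives 11800 nM. Compound 3 gives 12100 nM in this assay, a number that lies within the usual scatter of the number for compound 1, so the two cannot be told apart. Compound 2 is reported as "not active" (no number reported) in this assay, with no number attached.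

Compound 4 `CCC[C@@H]1O[C@H](COCc2ccccc2)[C@@H](OCc2ccccc2)[C@H](OCc2ccccc2)[C@H]1O` has not yet been measured. It differs from compound 1 in one place: propyl in place of vinyl on a saturated ring carbon. Within the data shown here, no measured pair shows a change of just this kind, so the size of the step can only be guessed. The two compounds with numbers sit close together, while compound 2 gives none, so a saturated chain may leave the number roughly unchanged or push it weaker. Compound 4 is expected to show a step of a 1.3-fold higher number from compound 1 to compound 4 (0.10 log units; within the scatter), small or none beyond the scatter. For compound 4 the estimated value is 15000 nM, expected to fall between 6000 nM and 40000 nM.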

Compound 4, half-maximal inhibitory concentration: 11700 nM
Compound 4: middle estimate off by 1.3-fold (0.11 log units), on the high side; the range from low to high includes it.
By their numbers in this assay, from the lowest: compounds 4, 1 and 3 (each within the scatter of the next).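

Among these compounds, putting propyl in place of vinyl on the saturated ring carbon next to the ring oxygen gives a 1.0-fold lower number from compound 1 to compound 4 (0.00 log units; within the scatter) in this assay, the first direct comparison in which only this group differs. For this pair, the double bond of the vinyl group can be lost and one carbon gained with no difference that can be told from the scatter, so the double bond is not needed to keep activity at this level. Nothing measured here gives a reason for this result.

Vinyl and propyl both contain only carbon, so this pair cannot show what an amine, a carboxylic acid or a longer chain would do at this position. Among the compounds shown here, compound 2 still has no number, so no step to it can be sized.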